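Notes on Compound 3: Hydroxy for 1-Ethoxyethenyl

The source may hold more compounds than are shown below. What is called first, only, known or untested is meant among the compounds shown, and "the series" means these compounds.

Measured so far:
compound 1 `C=C(OCC)c1ccc(Nc2cccc3c2C(=O)N(C2CCC(=O)NC2=O)C3=O)cc1` — 10%
compound 2 `CC(=O)c1ccc(Nc2ccc3c(c2)C(=O)N(C2CCC(=O)NC2=O)C3=O)cc1` — -2%

Both compounds were read in an assay on FRT-Jurkat cells for inhibition of nuclear factor NF-kappa-B complex (Homo sapiens), read by flow cytometry, with a stated time of 24 h, tested at 10 uM; on this read-out lower numbers stand for less inhibition and higher numbers for more inhibition at the one concentration tested (going by the name of the read-out). Compound 1 gives 10% and compound 2 gives -2%. For the measured compounds named here, compound 1 therefore stands highest of the two numbers, and the gap to compound 2 lies beyond the usual scatter; compound 2 differs from compound 1 in more than one place, so no single step connects them, and only the two values themselves are noted.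

Compound 3 `O=C1CCC(N2C(=O)c3cccc(Nc4ccc(O)cc4)c3C2=O)C(=O)N1` is not yet measured. It differs from compound 1 by a single change: hydroxy in place of 1-ethoxyethenyl on an aromatic carbon. Going by the values given here, nothing measured so far isolates this change, so the expectation rests on the low level of both numbers seen in this assay.

The step from compound 1 to compound 3 is expected to be small, a change of a number 2 percentage points lower from compound 1 to compound 3 (within the scatter), not beyond the scatter in either direction. Compound 3 is accordingly estimated at 8%, with a range from -8% to 24%.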

Compound 3, a percentage reported as inhibition, at one concentration (the size of the read-out at that concentration, not a potency): 4%
For compound 3 the middle estimate is 4 percentage points above the measured one; measured number inside the range.
By their numbers in this assay, from the lowest: compounds 2, 3 and 1 (each within the scatter of the next, the first and the last beyond it).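

In this assay, for the compounds shown here, the replacement of 1-ethoxyethenyl by hydroxy, on an aromatic carbon para to a large group, gives a number 6 percentage points lower from compound 1 to compound 3 (within the scatter), the first comparison that isolates one place. At this position, therefore, a group of 5 heavy atoms with a double bond and no hydrogen-bond donor is not told apart from a group of 1 heavy atom with 1 hydrogen-bond donor, although this single pair says nothing about other substituents. No accompanying measurement bears on this result, and the step remains a bare observation.

From the compounds shown here alone, it remains open whether an amine, a carboxylic acid or a longer chain such as butoxy on the same aromatic carbon would give a number that stands beyond the scatter from compound 1 or compound 3. Also open, going by these compounds, is whether hydroxy in place of 1-ethoxyethenyl would read the same way with the anilino group at another place on the shared core, and what either compound would give at any other concentration.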